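The source may report more compounds than this note shows. Statements on the series, on what has been measured and on what is new or still open speak of the compounds shown alone.

Working notes on the series built on the shared core, read in an ADME assay on WI-38 cells (Homo sapiens) for cytotoxicity, read by MTT assay, with a stated time of 72 h; on this read-out lower numbers stand for stronger inhibition and higher numbers for weaker inhibition. Compound 1 `O=C(CCc1cccc2c1B(O)OC2)Nc1cccc(I)c1` gives 71000 nM, compound 2 `O=C(CCc1cccc2c1B(O)OC2)Nc1cccc(-c2cccc(F)c2)c1` gives 37000 nM, and compound 3 `COc1ccc(-c2cccc(NC(=O)CCc3cccc4c3B(O)OC4)c2)cc1` gives 1400 nM. Compound 2 stands with compound 1 at the high end of these numbers, the step between them being a 1.9-fold lower number from compound 1 to compound 2 (0.28 log units; within the scatter). Compound 3 lies well apart, at a 26-fold lower number from compound 2 to compound 3 (1.42 log units; beyond the scatter), and the step from the iodo compound is a 51-fold lower number from compound 1 to compound 3 (1.71 log units; beyond the scatter).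

Next is compound 4 `O=C(CCc1cccc2c1B(O)OC2)Nc1cccc(-c2cccc(OC(F)(F)F)c2)c1`, with the change trifluoromethoxy in place of fluoro on an aromatic carbon, meta to a large group. Going by the values given here, no measured compound carries trifluoromethoxy. Among the compounds with values here, the only large step involving a change on the added phenyl ring is a 26-fold lower number from compound 2 to compound 3 (1.42 log units; beyond the scatter), and that is a different group, so it shows only that such a change can move the number a long way. A modest downward move is expected, most likely without leaving the scatter. The estimated step is a 1.7-fold lower number from compound 2 to compound 4 (0.23 log units; within the scatter). For compound 4 the expected value is 22000 nM, with an estimated range of 6000 nM to 70000 nM.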

Compound 4, half-maximal inhibitory concentration: 9800 nM
Estimate against measurement, compound 4: 2.2-fold (0.35 log units) above; low and high end bracket the measured number.
By their numbers in this assay, from the lowest: compound 3; then compound 4; then compounds 2 and 1 (each within the scatter of the next).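

In this assay, going by these compounds alone, trifluoromethoxy in place of fluoro, meta to a large group, gives a 3.8-fold lower number from compound 2 to compound 4 (0.58 log units; beyond the scatter), which shows that this position responds to a change beyond the scatter with a group other than the one in compound 3. The step is modest beside the large 26-fold lower number from compound 2 to compound 3 (1.42 log units; beyond the scatter), so on this ring, the two compounds shown with a change from compound 2 differ widely in how far the number moves. Nothing measured here accounts for the step from fluoro to trifluoromethoxy.

The compounds shown leave open whether the oxygen of trifluoromethoxy or the fluorines carry the step, which a trifluoromethyl group or a methoxy group in the same place would help separate. They also leave open how an amine or a carboxylic acid at this position would read.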